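Carbamate in place of a dienyl ether on a pyridone core

A few compounds are considered here, and "the series" means these few. Any claim that something is new, unique, unknown or untested is made for them only; others in the source may bear on it.

Compound 2, `CC(C)=CCC/C(C)=C/COc1cc(=O)n(CCCO)c2c1CC(C/C=C(\C)CCC=C(C)C)C(C)(C)C2`, gives 3.1% in a functional assay on PANC-1 cells (Homo sapiens) for inhibition, read by MTT assay, with a stated time of 24 h, tested at 10 uM; on this read-out lower numbers stand for less inhibition and higher numbers for more inhibition at the one concentration tested (going by the name of the read-out). Compound 1, `CC(C)=CCC/C(C)=C/CC1Cc2c(OCc3ccccc3)cc(=O)n(CCCO)c2CC1(C)C`, gives 1.5%, and the pair sit together: a number 1.6 percentage points higher from compound 1 to compound 2 (within the scatter). Compound 3, `COc1ccc(NC(=O)Oc2cc(=O)n(CCCO)c3c2CC(C/C=C(\C)CCC=C(C)C)C(C)(C)C3)cc1`, carries (4-methoxyphenyl)carbamoyl in place of 3,7-dimethylocta-2,6-dien-1-yl on an oxygen on an aromatic ring. Among the compounds with values here, the only measured step exchanges groups on the same oxygen but at a different bond, so it bears on the new change only loosely, and it was small. No step beyond the scatter is therefore expected, as a number 2.9 percentage points higher from compound 2 to compound 3 (within the scatter). Compound 3 is estimated to give 6%, with a range from -5% to 22%.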

Compound 3, a percentage reported as inhibition, at one concentration (the size of the read-out at that concentration, not a potency): 0%
The estimate for compound 3 lay 6 percentage points above the measured number; the measured number falls inside the stated range.
By their numbers in this assay, from the lowest: compounds 3, 1 and 2 (each within the scatter of the next).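

In this assay, a (4-methoxyphenyl)carbamoyl group on the oxygen on an aromatic ring, which brings a hydrogen-bond donor, gives a number 3.1 percentage points lower from compound 2 to compound 3 (within the scatter) against 3,7-dimethylocta-2,6-dien-1-yl and a number 1.5 percentage points lower from compound 1 to compound 3 (within the scatter) against benzyl. The three groups on this oxygen, with and without a carbamoyl link, thus give numbers within the scatter of one another. Nothing measured here explains this. On these data alone, whether an amine or a carboxylic acid on this oxygen would give a number beyond that scatter stays open.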